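From Trifluoromethyl to Chloro in Compound 3

This account rests on a few compounds, and the source may have more. Where it says the series, first, only, none or still open, it means among the compounds named here.

Compound 1 `COc1cc(NC(C)CCCNC(=O)Nc2cccc(Cl)c2)c2ncccc2c1`: 26000 nM
Compound 2 `COc1cc(NC(C)CCCNC(=O)NNC(=O)Nc2cccc(C(F)(F)F)c2)c2ncccc2c1`: 21000 nM

These two numbers come from a functional assay on SW-620 cells (Homo sapiens) for inhibition, read by MTT assay, with a stated time of 72 h; on this read-out lower numbers stand for stronger inhibition and higher numbers for weaker inhibition. There, compound 2 gives 21000 nM and compound 1 gives 26000 nM. The two values lie within the usual scatter of repeated measurements, so they cannot be ranked, and compound 2 stands level with compound 1.

Compound 3 `COc1cc(NC(C)CCCNC(=O)NNC(=O)Nc2cccc(Cl)c2)c2ncccc2c1` is compound 2 with a single exchange on the aromatic ring: chloro in place of trifluoromethyl on an aromatic carbon. This is chloro in place of trifluoromethyl on an aromatic carbon, meta to a large group. For the measured compounds named here, no measured pair here shows this exchange on its own, so the data give no direct guide to its size. The 3-chlorophenyl group does occur in compound 1, which gives 26000 nM, and that value offers only modest support for expecting little movement.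

The expected outcome in this assay is no step beyond the scatter, in neither direction. The estimate is a 1.0-fold higher number from compound 2 to compound 3 (0.02 log units; within the scatter). For compound 3 the expected value is 22000 nM, with an estimated range from 10000 nM to 48000 nM.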

Compound 3, half-maximal inhibitory concentration: 25000 nM
For compound 3 the middle estimate is 1.1-fold (0.06 log units) below the measured one; low and high end bracket the measured number.
By their numbers in this assay, from the lowest: compounds 2, 3 and 1 (each within the scatter of the next).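

The exchange of trifluoromethyl for chloro on the aromatic ring can now be read on its own: in this assay it gives a 1.2-fold higher number from compound 2 to compound 3 (0.08 log units; within the scatter) and so leaves compound 3 level with compound 2. This means that, in this pair, the position tolerates the smaller chloro group, with one heavy atom in place of four, without a change that can be told apart from the scatter. A second comparison also becomes possible, with the 3-chlorophenyl group held constant: placing ((3-chlorophenyl)carbamoyl)amino in place of 3-chlorophenyl on an amide-type nitrogen gives a 1.0-fold lower number from compound 1 to compound 3 (0.02 log units; within the scatter) and likewise shows no separable difference, while no available measurement explains either result.

These two groups at one place say little about how the same position would respond to a quite different substituent, such as an amine or a carboxylic acid. As far as these compounds go, it also remains open whether a longer chain on the shared core would bring the numbers away from the level that all three compounds share.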